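Acylamino series: chlorophenylcarbonyl to phenylcarbamoyl at compound 2

The source may report more compounds than this note shows. Statements on the series, on what has been measured and on what is new or still open speak of the compounds shown alone.

Measured so far in an assay on CHO cells for displacement of a labelled ligand from adenosine receptor A1 (Homo sapiens), tested at 10 uM; a lower number here means less inhibition, a higher number more inhibition at the concentration tested (going by the name of the read-out):
compound 1 `O=C(Nc1nn(-c2ccccc2)c(=O)c2ccccc12)c1ccccc1` gives 44%;
compound 2 `O=C(Nc1nn(-c2ccccc2)c(=O)c2ccccc12)c1ccc(Cl)cc1` gives 26%;
compound 3 `CC(=O)N(C(C)=O)c1nn(-c2ccccc2)c(=O)c2ccccc12` gives 47%.

Compound 2 stands lowest of the three numbers; compound 1 and compound 3 both lie above it, beyond the scatter. Within the data shown here, the only single-point step among the measured compounds is a number 18 percentage points lower from compound 1 to compound 2 (beyond the scatter), chloro in place of hydrogen on an aromatic carbon.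

Compound 4 `O=C(Nc1ccccc1)Nc1nn(-c2ccccc2)c(=O)c2ccccc12` is not yet measured. Its difference from compound 2 is anilino in place of 4-chlorophenyl on a carbonyl carbon, read one bond further out as (4-chlorophenyl)carbonyl to phenylcarbamoyl. Among the measured compounds shown here, no measured step exchanges a carbonyl-linked ring for a carbamoyl-linked one, so the chloro step bears only indirectly, the chlorine leaving together with its ring. An upward step is expected, a number 14 percentage points higher from compound 2 to compound 4 (beyond the scatter), with wide uncertainty. For compound 4 the estimate in this assay is 40%, range 18% to 62%.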

Compound 4, a percentage reported as inhibition, at one concentration (the size of the read-out at that concentration, not a potency): 44%
Compound 4: the middle estimate sits 4 percentage points below what was measured, and the stated range covers the measured number.
By their numbers in this assay, from the lowest: compound 2; then compounds 1, 4 and 3 (each within the scatter of the next).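

In this assay, anilino and phenyl on the carbonyl carbon cannot be told apart, with no change at the digits printed from compound 1 to compound 4 (within the scatter). Anilino in place of 4-chlorophenyl gives a number 18 percentage points higher from compound 2 to compound 4 (beyond the scatter), so among compounds 1, 2 and 4 the lower number goes only with the 4-chlorophenyl group. Nothing available explains these numbers.
Open, as far as these compounds go, is whether chlorine on the anilino ring of compound 4 would lower the number as it does on the phenyl ring of compound 1. Also open, from the compounds shown here alone, is how morpholine or a longer alkyl chain on the carbonyl carbon would read.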